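The compounds below may be only part of what the source reports. "The series", "measured", "known", "first", "only" and "open" are said of these compounds alone.

Compound 1 `CCCOC(=O)CCC(=O)N1CCN(CCCOc2cc3c(Nc4ccc(F)c(Cl)c4)ncnc3cc2OC)CC1`, compound 2 `CCCCCOC(=O)CCC(=O)N1CCN(CCCOc2cc3c(Nc4ccc(F)c(Cl)c4)ncnc3cc2OC)CC1` and compound 3 `CCCCCCCCCCOC(=O)CCC(=O)N1CCN(CCCOc2cc3c(Nc4ccc(F)c(Cl)c4)ncnc3cc2OC)CC1` share one core and differ only in the length of a saturated chain attached through an oxygen next to a carbonyl group. In a functional assay on A549 cells (Homo sapiens) for cytotoxicity, read by MTT assay, with a stated time of 24 h, tested at 20 uM (on this read-out higher numbers stand for a weaker effect at the one concentration tested and lower numbers for a stronger effect), compound 3 gives 88.2%. Compound 1 gives 87% and compound 2 gives 81.2%, so all three numbers sit within the scatter of one another. The chain lengthenings already measured gave a number 5.8 percentage points lower from compound 1 to compound 2 (within the scatter), a number 1.2 percentage points higher from compound 1 to compound 3 (within the scatter) and a number 7 percentage points higher from compound 2 to compound 3 (within the scatter). Compound 4 `CCCCCCCCCCCCCCCCCCCOC(=O)CCC(=O)N1CCN(CCCOc2cc3c(Nc4ccc(F)c(Cl)c4)ncnc3cc2OC)CC1` lengthens the chain once more: nonyl in place of hydrogen on a saturated chain carbon, ten or more bonds along the chain from an oxygen next to a carbonyl group. Because those earlier lengthenings gave a number 1.2 percentage points higher from compound 1 to compound 3 (within the scatter) and a number 7 percentage points higher from compound 2 to compound 3 (within the scatter), the step expected for compound 4 is a number 2.2 percentage points lower from compound 3 to compound 4 (within the scatter), nothing beyond the scatter. Compound 4 is therefore estimated at 86%, between 76% and 95%.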

Compound 4, a percentage reported as activity, at one concentration (the size of the read-out at that concentration, not a potency): 94.8%
Estimate against measurement, compound 4: 8.8 percentage points below; low and high end bracket the measured number.
By their numbers in this assay, from the lowest: compounds 2, 1, 3 and 4 (each within the scatter of the next, the first and the last beyond it).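

Adding nonyl this far out on the saturated chain in this assay gives a number 6.6 percentage points higher from compound 3 to compound 4 (within the scatter), so even this large addition of carbon produces no step beyond the scatter. Across the whole series, however, compound 2 at 81.2% and compound 4 at 94.8% are the first pair whose values lie beyond the scatter of each other. No measurement shown offers an explanation for this result. Still open, on these data alone, is whether an amine or a carboxylic acid on this chain, in place of nonyl, would give a clearly different number.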